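A few compounds are considered here, and "the series" means these few. Any claim that something is new, unique, unknown or untested is made for them only; others in the source may bear on it.

In an ADME assay on Huh-7 cells (Homo sapiens) for cytotoxicity, with a stated time of 72 h (on this read-out higher numbers stand for lower toxicity in this test and lower numbers for higher toxicity in this test), compound 1 `CC(C)CCn1nc(-c2cccs2)c(O)c(C2=NS(=O)(=O)c3cc(N(C(C)C)S(C)(=O)=O)ccc3N2)c1=O` gives "not determined" (no result reported), so it offers no number to work from. Compound 2 `CC(C)CCn1nc(-c2ccccc2)c(O)c(C2=NS(=O)(=O)c3cc(NS(C)(=O)=O)ccc3N2)c1=O` stands at > 1000 nM, and this is a limit of the assay rather than a number. Compound 3 `CC(C)CCn1nc(C2=CCCC2)c(O)c(C2=NS(=O)(=O)c3cc(NS(C)(=O)=O)ccc3N2)c1=O` carries cyclopent-1-en-1-yl in place of phenyl on an aromatic carbon. Going by the values given here, no measured pair shows what this swap does, so no change beyond the usual scatter is expected in this assay. The expected step is a step that the limit leaves unreadable from compound 2 to compound 3. The estimate for compound 3 is 1800 nM, with an expected range of 1000 nM to 10000 nM.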

Compound 3, half-maximal cytotoxic concentration: > 1000 nM
Compound 3: no number, only a limit (the forecaster's own chance of this, stated with the estimate: 80%); the middle value does not contradict the limit.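

No step can be read between compound 2 and compound 3: each gives a limit of the assay, not a number. Going by these compounds, what cyclopent-1-en-1-yl in place of phenyl does in this assay stays open.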